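Swapping the aryl group on a diketopiperazine-type core

A few compounds are considered here, and "the series" means these few. Any claim that something is new, unique, unknown or untested is made for them only; others in the source may bear on it.

Measured so far:
Compound 1, `C=CCn1c(=O)/c(=C\c2cc(Br)ccc2F)[nH]c(=O)/c1=C\c1ccccc1OC`, in a functional assay on A549 cells (Homo sapiens) for cytotoxicity, read by CCK-8 assay, with a stated time of 72 h; on this read-out higher numbers stand for weaker inhibition and lower numbers for stronger inhibition: "not active" (no number reported)
Compound 2, `COc1ccccc1/C=c1\c(=O)[nH]/c(=C/c2cccc(Cl)c2Cl)c(=O)n1C`, in this assay: 200 nM
Compound 3, `C=CCn1c(=O)/c(=C\c2ccc(Cl)c(Cl)c2)[nH]c(=O)/c1=C\c1ccccc1`, in this assay: "not active" (no number reported)

Compound 1 stands without a single number: in this assay it was reported as not active, and compound 3 is a further entry with the same outcome. Within the data shown here, only compound 2 carries a number in this assay, which marks it as the one compound of the three with measurable cytotoxicity on these cells.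

Compound 4, `C=CCn1c(=O)/c(=C\c2cc(F)ccc2C)[nH]c(=O)/c1=C\c1ccccc1OC`, has not yet been measured. It differs from compound 1 in one place: 5-fluoro-2-methylphenyl in place of 5-bromo-2-fluorophenyl on a double-bonded chain carbon bound to an aromatic carbon. The rest of the shared core is unchanged.

Among the measured compounds shown here, no step between two measured compounds is available to anchor this change, so the expectation rests on what the measured compounds show. For the measured compounds named here, compound 1 gives no number in this assay, and compound 3 gives none either, while compound 2 is the sole entry with a value. On this basis the change from compound 1 to compound 4 is expected to produce no shift beyond the usual scatter, and the most likely outcome is again a report without a number.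

Compound 4 is expected to give about 30000 nM in this assay, with a range from 3000 nM to 100000 nM, and with a high chance that only a limit is reported.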

Compound 4, half-maximal inhibitory concentration: 4900 nM
For compound 4 the middle estimate is 6.1-fold (0.79 log units) above the measured one, within the range that was stated.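

Among these compounds, compound 4 gives 4900 nM in this assay and compound 1 gives "not active" (no number reported) there, so with only one number the pair yields no readable step. Nothing measured here bears on why compound 4 gives a number. The compounds shown leave open how large a change in cytotoxicity comes from replacing 5-bromo-2-fluorophenyl with 5-fluoro-2-methylphenyl.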